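This account rests on a few compounds, and the source may have more. Where it says the series, first, only, none or still open, it means among the compounds named here.

Measured compounds:
compound 1 `CNC(=O)[C@@]12C[C@@H]1[C@@H](n1cnc3c(NC)nc(C#Cc4ccc(OC)cc4)nc31)[C@H](O)[C@@H]2O` — 0.63 nM
compound 2 `CNC(=O)[C@@]12C[C@@H]1[C@@H](n1cnc3c(NC)nc(C#Cc4cccnn4)nc31)[C@H](O)[C@@H]2O` — 3.53 nM
compound 3 `CNC(=O)[C@@]12C[C@@H]1[C@@H](n1cnc3c(NC)nc(C#Cc4cnn(C)c4)nc31)[C@H](O)[C@@H]2O` — 2.34 nM

In an assay on CHO cells for displacement of a labelled ligand from adenosine receptor A3 (Homo sapiens), read by scintillation counting, with a stated time of 60 min (a lower number here means a stronger inhibitor, a higher number a weaker inhibitor), compound 3 holds the second highest number of the three: compound 1 sits well apart, since a 3.7-fold higher number from compound 1 to compound 3 (0.57 log units; beyond the scatter), whereas compound 2 does not, since a 1.5-fold lower number from compound 2 to compound 3 (0.18 log units; within the scatter). Compound 4 `CCc1ccc(C#Cc2nc(NC)c3ncn([C@H]4[C@H](O)[C@H](O)[C@]5(C(=O)NC)C[C@H]45)c3n2)o1` arises from compound 3 by 5-ethylfuran-2-yl in place of 1-methyl-1H-pyrazol-4-yl on a triple-bonded carbon. Going by the values given here, no measured step swaps one five-membered heteroaryl for another on this triple-bonded carbon; the nearest guides are a 3.7-fold higher number from compound 1 to compound 3 (0.57 log units; beyond the scatter) and a 5.6-fold higher number from compound 1 to compound 2 (0.75 log units; beyond the scatter), both modest, and the step from compound 2 to compound 3 is within the scatter. A small move toward a lower number is therefore expected, a 1.5-fold lower number from compound 3 to compound 4 (0.17 log units; within the scatter), and compound 4 is estimated at 1.6 nM, between 0.5 nM and 5 nM.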

Compound 4, inhibition constant: 1.5 nM
Compound 4: the middle estimate sits 1.1-fold (0.03 log units) above what was measured; the range from low to high includes it.
By their numbers in this assay, from the lowest: compound 1; then compounds 4, 3 and 2 (each within the scatter of the next, the first and the last beyond it).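

In this assay, the 5-ethylfuran-2-yl, with its single ring oxygen and an ethyl group, serves on the triple-bonded carbon as well as the 1-methyl-1H-pyrazol-4-yl: a 1.6-fold lower number from compound 3 to compound 4 (0.19 log units; within the scatter). Against the other two groups it falls on either side, with a 2.4-fold lower number from compound 2 to compound 4 (0.37 log units; beyond the scatter) and a 2.4-fold higher number from compound 1 to compound 4 (0.38 log units; beyond the scatter), so the 4-methoxyphenyl of compound 1 remains ahead of it. No evidence at hand bears on why these steps fall as they do.

On these data alone, whether the ethyl group matters stays open: how a furan-2-yl without it, or one carrying a longer chain or an amine, would compare cannot be told from these compounds.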